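The compounds below may be only part of what the source reports. "The series", "measured", "known", "first", "only" and "open" are said of these compounds alone.

Values in a functional assay on the whole organism for activation, with Mus musculus as the target, with a stated time of 60 min; on this read-out higher numbers stand for an effect only at larger amounts of compound and lower numbers for an effect already at smaller amounts:
- Compound 1 `O=C1NC(=O)N(/N=C/c2ccc(-c3ccc(Cl)c(Cl)c3)o2)C1O`: 109 mg/kg
- Compound 2 `N#Cc1ccc(-c2ccc(/C=N/N3C(=O)NC(=O)C3O)o2)cc1`: > 1000 mg/kg
- Compound 3 `O=C1CN(/N=C/c2ccc(-c3cccc(C(F)(F)F)c3)o2)C(=O)N1`: 647 mg/kg

Of the two true numbers in this set, compound 3 has the higher, at 647 mg/kg. Compound 1 gives 109 mg/kg. The gap between these two compounds lies beyond the scatter, so a larger amount of compound 3 is needed for the effect. Compound 2 gives > 1000 mg/kg, which is a limit of the assay and not a number.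

Compound 4 `O=C1NC(=O)N(/N=C/c2ccc(-c3cccc(C(F)(F)F)c3)o2)C1O` has not yet been measured in this assay. Its structure departs from that of compound 3 in one place, with hydroxy in place of hydrogen on a saturated ring carbon.

Going by the values given here, no measured pair isolates this change, so the expectation rests on indirect evidence. Compound 1 carries the 5-hydroxy-2,4-dioxoimidazolidin-1-yl group and gives 109 mg/kg, but it differs from compound 3 elsewhere as well. Compound 2 carries the same group and goes against any simple gain from it, with its limit of > 1000 mg/kg.

The expected change, a 2.2-fold lower number from compound 3 to compound 4 (0.33 log units; beyond the scatter), is therefore a moderate move towards a lower number, only just beyond the scatter. The estimate for compound 4 is 300 mg/kg, with an expected range from 90 mg/kg to 1000 mg/kg.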

Compound 4, dose for half-maximal effect: 166 mg/kg
Beside the measured number, compound 4's estimate is 1.8-fold (0.26 log units) above it; low and high end bracket the measured number.
By their numbers in this assay, from the lowest: compounds 1 and 4 (each within the scatter of the next); then compound 3. At a limit, above all of these: compound 2.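

In this assay, the change from 2,4-dioxoimidazolidin-1-yl to 5-hydroxy-2,4-dioxoimidazolidin-1-yl now has a measured pair of its own, which gives a 3.9-fold lower number from compound 3 to compound 4 (0.59 log units; beyond the scatter). Going by these compounds alone, the earlier compounds showed this group only alongside differences elsewhere in the structure, so this is the first step that isolates hydroxy in place of hydrogen on this saturated ring carbon. With everything else held constant, the step runs towards a lower number, meaning that the effect appears at smaller amounts of compound, and the position therefore tolerates hydroxy in this read-out.

This single pair cannot show whether the step carries over to other substituents on the shared core, and compound 2 offers no second reading, as its value is a limit of the assay and not a number: the limit of > 1000 mg/kg in this assay, at which 1 of the 4 values shown sits. The compounds shown also leave open how a methoxy group, an amine or a carboxylic acid on this saturated ring carbon would compare with hydroxy.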